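Ester side chain swap at two positions of the shared core

A few compounds are considered here, and "the series" means these few. Any claim that something is new, unique, unknown or untested is made for them only; others in the source may bear on it.

Compound 1 `N[C@@H](CC(=O)OC[C@H]1O[C@@H](n2cc(F)c(=O)[nH]c2=O)C[C@@H]1O)C(=O)O` and compound 2 `CC(C)[C@H](N)C(=O)OC[C@H]1O[C@@H](n2cc(F)c(=O)[nH]c2=O)C[C@@H]1O` carry their ester on one hydroxyl oxygen of the shared core, while compound 3 `N[C@@H](CC(=O)O[C@H]1C[C@H](n2cc(F)c(=O)[nH]c2=O)O[C@@H]1CO)C(=O)O` and compound 4 `CC(C)[C@H](N)C(=O)O[C@H]1C[C@H](n2cc(F)c(=O)[nH]c2=O)O[C@@H]1CO` carry it on the other. Compound 3 and compound 1 are built from the same atoms joined differently; the difference between the two cores is not broken down here.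

In a functional assay on MDA-MB-231 cells (Homo sapiens) for inhibition, read by MTT assay, with a stated time of 24 h (a lower number here means a stronger inhibitor of growth, a higher number a weaker inhibitor of growth), compound 1 gives 29300000 nM and compound 2 gives 38100000 nM. The change between them is 1-amino-2-methylpropyl in place of 2-amino-2-carboxyethyl on a carbonyl carbon, and it made a step of a 1.3-fold higher number from compound 1 to compound 2 (0.11 log units; within the scatter). In this assay compound 3 gives 37600000 nM; its number and that of compound 2 lie within the scatter of each other, and the same holds against compound 1.

Compound 4 has not been measured. It differs from compound 3 by 1-amino-2-methylpropyl in place of 2-amino-2-carboxyethyl on a carbonyl carbon. This is the same change as between compound 1 and compound 2, made at a carbonyl carbon with the same surroundings, and it occurs twice among the four compounds. A step of a 1.2-fold higher number from compound 3 to compound 4 (0.08 log units; within the scatter) is expected because the same change gave a 1.3-fold higher number from compound 1 to compound 2 (0.11 log units; within the scatter), a step within the scatter. Compound 4 is therefore expected to give 45000000 nM in this assay, with an estimated range from 25000000 nM to 80000000 nM. Nothing among the three measured compounds points to a larger step.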

Compound 4, concentration for 50% growth inhibition: 32400000 nM
Estimate against measurement, compound 4: 1.4-fold (0.14 log units) above; the measured number falls inside the stated range.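

In this assay, putting 1-amino-2-methylpropyl in place of 2-amino-2-carboxyethyl on the carbonyl carbon gives a 1.2-fold lower number from compound 3 to compound 4 (0.06 log units; within the scatter). Set beside the same change on the core of compound 1, this step does not differ from the earlier one: the same change on two cores in this assay, a 1.3-fold higher number (0.11 log units; within the scatter) from compound 1 to compound 2 and a 1.2-fold lower number (0.06 log units; within the scatter) from compound 3 to compound 4, 1.5-fold (0.18 log units) apart, within the scatter of two such steps. For the compounds shown here, in these two pairs, the change therefore carries from one core to the other with no step that can be told from the scatter, but since neither step lies beyond the scatter, this shows only that the change has no readable effect on either core in this assay, not that a change with a readable effect would carry across in the same way, and two pairs set no rule for the wider series.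

The compounds shown leave open whether a side chain of another kind on either hydroxyl oxygen, such as a longer carbon chain or a chain ending in an aromatic ring, would give a step beyond the scatter in this assay. They also leave open how the shared core with both hydroxyl groups free reads in this assay, so the effect of the ester itself cannot be judged from these pairs.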